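The source may report more compounds than this note shows. Statements on the series, on what has been measured and on what is new or still open speak of the compounds shown alone.

Of the compounds shown here, three sharing one core have been measured so far: compound 1 `Oc1ccc(O)c(/C=N/c2ccc(OCc3ccccc3)cc2)c1`, compound 2 `Oc1ccc(/C=N/c2ccc(OCc3ccccc3)cc2)c(O)c1O` and compound 3 `Oc1cc(O)c(/C=N/c2ccc(OCc3ccccc3)cc2)c(O)c1`. In a functional assay, with a stated time of 30 min (a higher number here means a weaker inhibitor, a lower number a stronger inhibitor), compound 1 gives 21300 nM, which is the lowest of the three numbers. Within the data shown here, compound 3 gives 23900 nM in this assay, a number that lies within the usual scatter of the one for compound 1, so the two cannot be told apart. Among the measured compounds shown here, compound 2 gives 43400 nM in this assay, a number that stands beyond the scatter above the one for compound 1.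

Compound 4 `Cc1cccc(/C=N/c2ccc(OCc3ccccc3)cc2)c1O` has not been measured. It differs from compound 1 in one place: 2-hydroxy-3-methylphenyl in place of 2,5-dihydroxyphenyl on a carbon with a double bond to nitrogen. For the measured compounds named here, no measured pair shows the effect of such a change, so the expectation rests only on the spread of the three numbers above, which is modest. A small rise in this assay, or none beyond the scatter, is expected from compound 1 to compound 4, a step of about a 1.5-fold higher number from compound 1 to compound 4 (0.18 log units; within the scatter). Compound 4 is therefore expected to give about 32000 nM in this assay, within a range from 11000 nM to 95000 nM.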

Compound 4, half-maximal inhibitory concentration: > 200000 nM
Compound 4 gave a limit, no number; the forecaster's own chance of this, stated with the estimate: 15%; middle value at least 6.2-fold (0.79 log units) away from the limit.
By their numbers in this assay, from the lowest: compounds 1, 3 and 2 (each within the scatter of the next, the first and the last beyond it). At a limit, above all of these: compound 4.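

Among these compounds, this is the first measured step at this place on the shared core, and it shows that the place is sensitive to what it carries: 2-hydroxy-3-methylphenyl in place of 2,5-dihydroxyphenyl gives an at least 9.3-fold higher number from compound 1 to compound 4 (0.97 log units; beyond the scatter) in this assay and so lies clearly beyond the scatter. Compound 4 gave a limit and no number: the limit of > 200000 nM in this assay, at which 1 of the 4 values shown sits. As far as these compounds go, the step therefore marks only the smallest possible size of the change, and its true size remains unknown.

This single step swaps a hydroxyl for a methyl as one change, so the compounds shown cannot tell whether losing the hydroxyl, gaining the methyl or both together accounts for the rise. From the compounds shown here alone, it also remains open how an amine, a carboxylic acid or a longer chain would fare on this ring in place of the methyl.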